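Three pyridylquinolines compared for liver microsome stability

A few compounds are considered here, and "the series" means these few. Any claim that something is new, unique, unknown or untested is made for them only; others in the source may bear on it.

Compounds measured so far:
- compound 1, `O=S(=O)(c1cccc(-c2ccc3nccc(-c4ccncc4)c3n2)c1)N1CCC(O)CC1`: 5%
- compound 2, `NS(=O)(=O)c1ccc(-c2ccc3nccc(-c4ccncc4)c3n2)cc1`: 76%

The shared core carries an aryl sulfonyl group in each case, and the two measured compounds were run in an ADME assay on microsomes from liver (Homo sapiens) for metabolic stability, read by LC-MS, using NADPH, with a stated time of 30 min, tested at 0.1 uM; a lower number here means that less of the compound is left, a higher number that more of the compound is left. Compound 1 gives 5% and so stands lowest of the two numbers. Compound 2 gives 76%, a gap to compound 1 that lies beyond the usual scatter of the measurement.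

Compound 3, `CS(=O)(=O)Nc1cccc(-c2ccc3nccc(-c4ccncc4)c3n2)c1`, has not yet been measured in this assay. It differs from compound 1 at a single place, (methanesulfonamido in place of (4-hydroxypiperidin-1-yl)sulfonyl on an aromatic carbon), so that the ring of the leaving group is gone and a smaller group with one hydrogen-bond donor takes its place.

Within the data shown here, no step between two measured compounds matches this change, so the expectation rests on the two values alone. With compound 2 as the only higher anchor, compound 3 is expected to move upward from compound 1 by a step of a number 40 percentage points higher from compound 1 to compound 3 (beyond the scatter), beyond the scatter. In this assay compound 3 is therefore estimated at 45%, within a range of 15% to 80%.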

Compound 3, percent of the compound remaining: 59%
Compound 3: middle estimate off by 14 percentage points, on the low side, and the stated range covers the measured number.
By their numbers in this assay, from the lowest: compound 1; then compound 3; then compound 2.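

In this assay, replacing (4-hydroxypiperidin-1-yl)sulfonyl with methanesulfonamido on this aromatic carbon, meta to a large group, gives a number 54 percentage points higher from compound 1 to compound 3 (beyond the scatter). Among these compounds, this is the first single-place comparison in the set, and it shows that the low number of compound 1 is not fixed by the shared core alone, as the number moves strongly when only this group changes. The step goes with the loss of the six-membered non-aromatic ring and a drop from 10 heavy atoms to 5 in the group, but nothing measured here explains the size of the step or links it to any property of either group.

The compounds shown leave open which part of the change carries the step, as the ring, the hydroxyl, the size of the group and the way the sulfonyl is attached all change together. A piperidin-1-ylsulfonyl group lacking the hydroxyl, or an open-chain dimethylaminosulfonyl group, at the same place would begin to separate these parts.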